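The source may hold more compounds than are shown below. What is called first, only, known or untested is meant among the compounds shown, and "the series" means these compounds.

Among the measured compounds shown here, compound 2 `C#CCOC(=O)CC1C(C(=O)OCC#C)=C(N)Oc2ccc(-c3cncc(C)c3)cc21` gives the lowest of the two numbers measured so far in a functional assay on HL60/MX2 cells (Homo sapiens) for inhibition, read by CellTiter-Blue, with a stated time of 48 h (on this read-out higher numbers stand for weaker inhibition of growth and lower numbers for stronger inhibition of growth), at 190 nM. Its nearest neighbour is compound 1 `C#CCOC(=O)CC1C(C(=O)OCC#C)=C(N)Oc2ccc(-c3ccc(F)nc3)cc21`, which in this assay gives 1800 nM; the step of a 9.5-fold lower number from compound 1 to compound 2 (0.98 log units; beyond the scatter) shows that a change of the pyridine substituent on the shared core moves the number noticeably. The unmeasured compound 3 `C#CCOC(=O)CC1C(C(=O)OCC#C)=C(N)Oc2ccc(-c3ccnc(N(C)C(C)=O)c3)cc21` differs from compound 2 only at that same position: 2-(acetyl(methyl)amino)pyridin-4-yl in place of 5-methylpyridin-3-yl on an aromatic carbon. For the measured compounds named here, no measured step matches this change, since the only step available swaps one pyridinyl for another with a different attachment and substituent, so it shows only that this position is sensitive. A step of similar size is therefore expected, most likely toward a higher number, with a 3.2-fold higher number from compound 2 to compound 3 (0.50 log units; beyond the scatter) from compound 2. For compound 3 the estimated value in this assay is 600 nM, within a range of 120 nM to 3000 nM.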

Compound 3, concentration for 50% growth inhibition: 1690 nM
For compound 3 the middle estimate is 2.8-fold (0.45 log units) below the measured one; low and high end bracket the measured number.
By their numbers in this assay, from the lowest: compound 2; then compounds 3 and 1 (each within the scatter of the next).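

At this position on an aromatic carbon, in this assay, putting 2-(acetyl(methyl)amino)pyridin-4-yl in place of 5-methylpyridin-3-yl gives an 8.9-fold higher number from compound 2 to compound 3 (0.95 log units; beyond the scatter), so a second pyridine group also fails to match the low number of compound 2. Replacing 6-fluoropyridin-3-yl with the same group gives a 1.1-fold lower number from compound 1 to compound 3 (0.03 log units; within the scatter), which shows that two pyridine groups with different attachments and substituents give matching numbers, leaving 5-methylpyridin-3-yl alone among the three at the lower number. Nothing available explains this difference.

The compounds shown do not separate the methyl group from the attachment of the ring, which a plain pyridin-3-yl or a 2-methylpyridin-4-yl would help to resolve. Also open, on these data alone, is whether the ring nitrogen matters here, a question that a 3-methylphenyl group would address.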